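Removing a Ring Hydroxy from a Compound at the Limit

This account rests on a few compounds, and the source may have more. Where it says the series, first, only, none or still open, it means among the compounds named here.

Compound 1 `C#Cc1cn([C@@H]2O[C@H](CO)[C@@H](O)[C@@H]2O)c(=O)[nH]c1=O`: in an ADME assay on L1210/0 cells (Mus musculus) for cytotoxicity, with a stated time of 48 h (on this read-out higher numbers stand for weaker inhibition and lower numbers for stronger inhibition), compound 1 gives 168000 nM.
Compound 2 `CC(C)(C)C#Cc1cn([C@@H]2O[C@H](CO)[C@@H](O)[C@@H]2O)c(=O)[nH]c1=O`: in this assay compound 2 gives only a limit of the assay, > 200000 nM.
Compound 3 `Nc1nc2c(nc(N)n2COCCO)c(=O)[nH]1`: in this assay compound 3 likewise gives only a limit of the assay, > 200000 nM.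

Compound 2 therefore stands at the limit rather than at a number, and it is not alone there: the limit of > 200000 nM in this assay, at which 2 of the 3 values shown sit. Among the measured compounds shown here, only one pair of measured compounds differs in a single place, and that step is an at least 1.1-fold higher number from compound 1 to compound 2 (0.07 log units; that floor lies within the scatter); its floor lies within the scatter, so it shows no clear movement in either direction.

Compound 4 `CC(C)(C)C#Cc1cn([C@H]2C[C@H](O)[C@@H](CO)O2)c(=O)[nH]c1=O` differs from compound 2 in one place: hydrogen in place of hydroxy on a saturated ring carbon. For the measured compounds named here, no measured step touches a change of this kind, so nothing among the measured compounds points to a direction, and no movement beyond the scatter in this assay is expected.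

Compound 4 is thus expected close to the limit at which compound 2 sits, with a real chance that again only a limit is reported; the estimate is 200000 nM, within a range from 50000 nM to 800000 nM. That estimate means an expected step of a number no higher from compound 2 to compound 4 (the limit leaves the size open), staying within the scatter.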

Compound 4, half-maximal inhibitory concentration: > 200000 nM
Compound 4: no number, only a limit; the forecaster's own chance of this, stated with the estimate: 60%; the middle value sits exactly at the limit.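

In this assay compound 4 gives only a limit of the assay, > 200000 nM. Compound 2 also gives only a limit, so no step between compound 2 and compound 4 can be read: the limit of > 200000 nM in this assay, at which 3 of the 4 values shown sit.

The compounds shown leave open whether hydrogen in place of hydroxy on a saturated ring carbon shifts the read-out in either direction.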